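This account rests on a few compounds, and the source may have more. Where it says the series, first, only, none or still open, it means among the compounds named here.

Measured in a functional assay on A549 cells (Homo sapiens) for cytotoxicity, with a stated time of 48 h; on this read-out lower numbers stand for stronger inhibition and higher numbers for weaker inhibition:
- Compound 1 `CCCCOc1ccc2oc(/C=C/[S+](C)[O-])cc(=O)c2c1`: 1400 nM
- Compound 2 `CCC(=O)Oc1ccc2oc(/C=C/[S+](C)[O-])cc(=O)c2c1`: 2400 nM
- Compound 3 `COc1ccc2oc(/C=C/[S+](C)[O-])cc(=O)c2c1`: 1600 nM

Compound 3 sits within the scatter of both other compounds, as a 1.1-fold higher number from compound 1 to compound 3 (0.06 log units; within the scatter) and a 1.5-fold lower number from compound 2 to compound 3 (0.18 log units; within the scatter) show. Compound 4 `C[S+]([O-])/C=C/c1cc(=O)c2cc(OC(=O)C(C)(C)C)ccc2o1` differs from it by (tert-butyl)carbonyl in place of methyl on an oxygen on an aromatic ring, with (tert-butyl)carbonyl in place of methyl on an oxygen on an aromatic ring. Among the measured compounds shown here, the closest precedent is a 1.5-fold lower number from compound 2 to compound 3 (0.18 log units; within the scatter), which also exchanges propanoyl and methyl on that oxygen. a 1.7-fold higher number from compound 1 to compound 2 (0.23 log units; within the scatter) likewise stays within the scatter. No step beyond the scatter is therefore expected in this assay, only perhaps a slightly higher number. The estimated change is a 1.3-fold higher number from compound 3 to compound 4 (0.10 log units; within the scatter). For compound 4 the expected value is 2000 nM, with an estimated range from 1000 nM to 4000 nM.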

Compound 4, half-maximal inhibitory concentration: 1600 nM
Estimate against measurement, compound 4: 1.3-fold (0.10 log units) above; measured number inside the range.
By their numbers in this assay, from the lowest: compounds 1, 3, 4 and 2 (each within the scatter of the next).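

In this assay, (tert-butyl)carbonyl in place of methyl on the oxygen gives no change at the digits printed from compound 3 to compound 4 (within the scatter), so this much larger group, with its added carbonyl, still leaves the number within the scatter. The remaining steps, a 1.5-fold lower number from compound 2 to compound 4 (0.18 log units; within the scatter) and a 1.1-fold higher number from compound 1 to compound 4 (0.06 log units; within the scatter), also stay within it, so methyl, butyl, propanoyl and (tert-butyl)carbonyl on this oxygen cannot be told apart here. Nothing available bears on a reason for this result. The compounds shown leave open whether a free hydroxyl, or a chain ending in an amine or a carboxylic acid, on this position would give a step beyond the scatter.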